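The source may hold more compounds than are shown below. What is called first, only, known or untested is meant among the compounds shown, and "the series" means these compounds.

Measured in a functional assay on OVCAR-8 cells (Homo sapiens) for antiproliferative activity; a higher number here means a weaker inhibitor, a lower number a stronger inhibitor:
Compound 1 `Cn1ncc(Cl)c1-c1cc(C(=O)N[C@@H]2CN[C@H](CCO)C[C@H]2c2ccc(F)c(F)c2)oc1Cl`: 460 nM
Compound 2 `Cn1ncc(Cl)c1-c1cc(C(=O)N[C@@H]2CN[C@H](CC(=O)O)C[C@H]2c2ccc(Cl)c(Cl)c2)oc1Cl`: 5120 nM

Compound 2, at 5120 nM, has the higher of the two numbers and is therefore the weaker inhibitor. Its gap to compound 1 lies beyond the usual scatter of the measurement.

Compound 3 `Cn1ncc(Cl)c1-c1cc(C(=O)N[C@@H]2CN[C@H](CC(=O)NCCO)C[C@H]2c2ccc(Cl)c(Cl)c2)oc1Cl` is compound 2 with one change, (2-hydroxyethyl)amino in place of hydroxy on a carbonyl carbon. Read one bond further out, carboxy becomes (2-hydroxyethyl)carbamoyl. Among the measured compounds shown here, no pair of measured compounds differs in one place only, so the data hold no direct precedent for this change. The only hint is loose: compound 1, which has no carboxy group, gives 460 nM, but it also differs from compound 2 elsewhere. On that slender basis, a move towards a lower number in this assay is expected, beyond the scatter but not quite reaching compound 1. The expected change is a 5.7-fold lower number from compound 2 to compound 3 (0.76 log units; beyond the scatter). For compound 3 the estimated value is 900 nM, with an expected range of 250 nM to 3200 nM.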

Compound 3, half-maximal inhibitory concentration: 1450 nM
Compound 3: middle estimate off by 1.6-fold (0.21 log units), on the low side; the measured number falls inside the stated range.
By their numbers in this assay, from the lowest: compound 1; then compound 3; then compound 2.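

In this assay, among the compounds shown here, the change from hydroxy to (2-hydroxyethyl)amino gives a 3.5-fold lower number from compound 2 to compound 3 (0.55 log units; beyond the scatter) and is the first step in this set that alters one place only. It shows that on this carbonyl carbon, whose other neighbour is a saturated chain carbon, 4 heavy atoms can stand in place of 1 without any loss, and that the carboxy group is not needed for the activity seen with compound 2: compound 3, with (2-hydroxyethyl)carbamoyl there instead, has the lower number. No measurement at hand bears on why the number falls.

It remains open whether the step belongs to the amide itself or to its hydroxyethyl chain, as the compounds shown do not separate the two, and how a plain carbamoyl group or a (2-aminoethyl)carbamoyl group would read in this assay is unknown. Also open, going by these compounds, is whether a longer chain on the amide nitrogen would lower the number further or raise it again.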